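The compounds below may be only part of what the source reports. "The series", "measured", "known", "first", "only" and "open" are said of these compounds alone.

Compounds measured:
compound 1 `CCOC(=O)c1cc(C)cc(NNC(=O)Nc2cc(Cl)nc(Cl)c2)n1`, in an assay on membranes from CHO cells for displacement of a labelled ligand from sphingosine 1-phosphate receptor 2 (Homo sapiens), read by radioligand binding, with a stated time of 15 min (on this read-out lower numbers stand for stronger inhibition and higher numbers for weaker inhibition), giving 300 nM
compound 2 `Cc1cc(NNC(=O)Nc2cc(Cl)nc(Cl)c2)ncc1-c1cnn(C)c1`, in this assay giving 1200 nM

Of these two, compound 2 gives the higher number in this assay, and compound 1 the lower one. Compound 3 `Cc1cc(NNC(=O)Nc2cc(Cl)nc(Cl)c2)ncc1-c1cn(C)nc1C` is not yet measured. It differs from compound 2 by one change: methyl in place of hydrogen on an aromatic carbon. Nothing measured here shows what such a methyl does on this ring, so the expected step from compound 2 to compound 3 in this assay is small, likely within the scatter, with no clear direction, as a 1.2-fold lower number from compound 2 to compound 3 (0.08 log units; within the scatter) expresses. Compound 3 is therefore estimated at 1000 nM, within a range of 350 nM to 3000 nM.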

Compound 3, half-maximal inhibitory concentration: 190 nM
Estimate against measurement, compound 3: 5.3-fold (0.72 log units) above; measured number outside the range, below it.
By their numbers in this assay, from the lowest: compounds 3 and 1 (each within the scatter of the next); then compound 2.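

In this assay the change from 1-methyl-1H-pyrazol-4-yl to 1,3-dimethyl-1H-pyrazol-4-yl gives a 6.3-fold lower number from compound 2 to compound 3 (0.80 log units; beyond the scatter) and so shows that the read-out responds to a single added methyl at this position. That carbon lies next to the ring nitrogen and next to the ring atom that bears a large group. The earlier compounds offered no such one-place comparison, and nothing measured here explains the step. Going by these compounds, whether an ethyl, a methoxy group or an amine at this carbon would keep the step remains open.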